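The source may hold more compounds than are shown below. What is called first, only, known or untested is meant among the compounds shown, and "the series" means these compounds.

Measured compounds:
compound 1, `COc1cc2nc(Cc3ccc(Cl)cc3)[nH]c(=O)c2cc1OC`: 9000 nM
compound 2, `COc1cc2nc(-c3ccccc3Cl)nc(N=[N+]=[N-])c2cc1OC`: 8000 nM

In a functional assay on HCT-116 cells (Homo sapiens) for cytotoxicity, read by MTT assay, with a stated time of 72 h (on this read-out higher numbers stand for weaker inhibition and lower numbers for stronger inhibition), compound 1 gives 9000 nM. In this assay compound 2 gives 8000 nM. Compound 2 holds the lowest of the two numbers, but its nearest neighbour, compound 1, sits within the scatter of it, so the two values show no difference that can be read as a change.

Compound 3, `COc1ccc(-c2nc(N=[N+]=[N-])c3cc(OC)c(OC)cc3n2)cc1`, has not yet been measured in this assay. It differs from compound 2 in one place: 4-methoxyphenyl in place of 2-chlorophenyl on an aromatic carbon. For the measured compounds named here, no measured pair shows what such a change does here, so there is no step to lean on. On the numbers of compound 2 alone, the estimate for compound 3 is made with a wide range.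

Compound 3 is expected to stay close to compound 2, with a step of a 1.3-fold higher number from compound 2 to compound 3 (0.10 log units; within the scatter) that need not reach beyond the scatter in either direction. Compound 3 is therefore estimated at 10000 nM in this assay, with a range from 2500 nM to 40000 nM.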

Compound 3, half-maximal inhibitory concentration: 10000 nM
Estimate against measurement, compound 3: no gap at the digits printed, and the stated range covers the measured number.
By their numbers in this assay, from the lowest: compounds 2, 1 and 3 (each within the scatter of the next).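

In this assay, for the compounds shown here, replacing 2-chlorophenyl with 4-methoxyphenyl on the aromatic carbon between two ring nitrogen atoms gives a 1.3-fold higher number from compound 2 to compound 3 (0.10 log units; within the scatter), and this is the first step that can be read for a change in one place. It shows that this position can carry either of these two aryl groups without a change that can be told from the scatter, even though the substituent on the phenyl ring and its place on that ring both differ. No measured evidence here bears on why the two groups read alike.

Going by these compounds alone, the single step cannot separate the swap of chlorine for methoxy from the shift in where the substituent sits, so 4-chlorophenyl or 2-methoxyphenyl would be needed to tell those two apart, and it says nothing about how a single such change would read on its own. It also leaves open whether a group of a different kind at this position, such as an amine, a carboxylic acid or a longer alkyl chain in place of the aryl ring, would move the number beyond the scatter.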